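Swapping Piperidine for Piperazine on a Butyl Chain

A few compounds are considered here, and "the series" means these few. Any claim that something is new, unique, unknown or untested is made for them only; others in the source may bear on it.

Three compounds have been measured in a functional assay on MCF7 cells (Homo sapiens) for cytotoxicity, read by MTT assay, with a stated time of 72 h; a higher number here means a weaker inhibitor, a lower number a stronger inhibitor:
Compound 1 , `CN1CCN(CCCCCCn2c3c(c4ccccc42)C(=O)c2c[n+]([O-])c4ccccc4c2C3=O)CC1`, gives 400 nM.
Compound 2 , `CN1CCN(CCCCCn2c3c(c4ccccc42)C(=O)c2c[n+]([O-])c4ccccc4c2C3=O)CC1`, gives 1260 nM.
Compound 3 , `O=C1c2c[n+]([O-])c3ccccc3c2C(=O)c2c1c1ccccc1n2CCCCN1CCCCC1`, gives 150 nM.

Compound 3 has the lowest number of the three, and both of its steps lie beyond the scatter: a 2.7-fold lower number from compound 1 to compound 3 (0.43 log units; beyond the scatter) and an 8.4-fold lower number from compound 2 to compound 3 (0.92 log units; beyond the scatter). Compound 4 , `O=C1c2c[n+]([O-])c3ccccc3c2C(=O)c2c1c1ccccc1n2CCCCN1CCNCC1`, has not yet been measured. It differs from compound 3 in one place: piperazin-1-yl in place of piperidin-1-yl on a saturated chain carbon, four bonds along the chain from an aromatic nitrogen.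

For the measured compounds named here, no measured step isolates this exchange. The two steps that reach compound 3 each change the amine and the chain length together, and the remaining step, a 3.2-fold higher number from compound 1 to compound 2 (0.50 log units; beyond the scatter), changes only the chain. All that can be said is that the shared core tolerates several basic amines on the chain, with numbers spread over a modest range. A modest rise from compound 3 is expected, a 2.0-fold higher number from compound 3 to compound 4 (0.30 log units; within the scatter), with wide uncertainty. Compound 4 is estimated at 300 nM, with a range from 100 nM to 900 nM.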

Compound 4, half-maximal inhibitory concentration: 12000 nM
The estimate for compound 4 lay 40-fold (1.60 log units) below the measured number; the whole stated range lies below it.
By their numbers in this assay, from the lowest: compound 3; then compound 1; then compound 2; then compound 4.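

For the compounds shown here, at this place on the chain, four bonds along from an aromatic nitrogen, the ring is far from interchangeable: in this assay, piperazin-1-yl in place of piperidin-1-yl keeps the six-membered ring and its heavy-atom total, adding a second nitrogen and a hydrogen-bond donor, yet gives an 80-fold higher number from compound 3 to compound 4 (1.90 log units; beyond the scatter) as the first clean reading of this exchange. A piperazine ring alone does not bring such a high number, since the compounds with a 4-methylpiperazine ring on longer chains also sit lower, as a 9.5-fold higher number from compound 2 to compound 4 (0.98 log units; beyond the scatter) and a 30-fold higher number from compound 1 to compound 4 (1.48 log units; beyond the scatter) show, although these two steps change the methyl group and the chain length together. Nothing measured here explains the size of the jump.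

A 4-methylpiperazin-1-yl group on the butyl chain would separate the effect of the methyl group from that of chain length. A morpholin-4-yl ring at the same place would show whether a different second ring atom is tolerated.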